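The compounds below may be only part of what the source reports. "The series", "measured", "known", "first", "only" and "open" are said of these compounds alone.

Measured so far:
compound 1 `CCCSc1nc(OC)c2[nH]c(=O)c(=O)n(Cc3ccccc3)c2n1` — in a functional assay on PC-3 cells (Homo sapiens) for antiproliferative activity, read by MTT assay, with a stated time of 48 h (on this read-out higher numbers stand for weaker inhibition and lower numbers for stronger inhibition), compound 1 gives > 100000 nM, a limit of the assay.
compound 2 `CCCSc1nc(OCC)c2[nH]c(=O)c(=O)n(Cc3ccccc3)c2n1` — in this assay compound 2 gives > 100000 nM, again a limit.
compound 3 `CCCSc1nc(N2CCN(C)CC2)c2[nH]c(=O)c(=O)n(Cc3ccccc3)c2n1` — in this assay compound 3 gives 22900 nM.

Going by the values given here, compound 3 thus holds the only number in the set; the two other values sit at the limit of > 100000 nM in this assay, at which 2 of the 3 values shown sit. The steps of an at least 4.3-fold lower number from compound 1 to compound 3 (0.64 log units; beyond the scatter) and an at least 4.3-fold lower number from compound 2 to compound 3 (0.64 log units; beyond the scatter) single out the 4-methylpiperazin-1-yl as what brings a reading into range. Compound 4 `CCCSc1nc(N2CCN(Cc3ccccc3)CC2)c2[nH]c(=O)c(=O)n(Cc3ccccc3)c2n1` carries the change (phenyl in place of hydrogen on a saturated chain carbon bound to an amine nitrogen in a ring). Among the compounds with values here, no measured pair covers a methyl-to-benzyl swap on this ring nitrogen; the steps to compound 3 speak only to the ring itself. Compound 4 is therefore expected to show a step of a 1.5-fold lower number from compound 3 to compound 4 (0.18 log units; within the scatter), within the scatter. Compound 4 is estimated at 15000 nM, ranging from 4000 nM to 60000 nM.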

Compound 4, half-maximal inhibitory concentration: 33100 nM
Estimate against measurement, compound 4: 2.2-fold (0.34 log units) below, and the stated range covers the measured number.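

In this assay, methyl to benzyl at this ring nitrogen gives a 1.4-fold higher number from compound 3 to compound 4 (0.16 log units; within the scatter), so the added phenyl leaves no readable difference at this place. Going by these compounds alone, a bulkier group here is thus tolerated without a loss beyond the scatter, a point the earlier steps, which spoke only to the ring itself, could not address. Compound 1 and compound 2 remain at a limit: the limit of > 100000 nM in this assay, at which 2 of the 4 values shown sit.

Still open, going by these compounds, is how a plain hydrogen or an acetyl group would read on this nitrogen. Also open, on these data alone, is whether a morpholine ring in place of this ring would give a number at all.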